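Ester to Amide on Two Cores: Solubility Outlook

A few compounds are considered here, and "the series" means these few. Any claim that something is new, unique, unknown or untested is made for them only; others in the source may bear on it.

Measured compounds:
Compound 1, `COC(=O)c1cccc(NC(=O)c2cc3cc([N+](=O)[O-])ccc3o2)c1`: 25 ug/mL
Compound 2, `NC(=O)c1cccc(NC(=O)c2cc3cc([N+](=O)[O-])ccc3o2)c1`: 20 ug/mL
Compound 3, `COC(=O)c1cccc(NC(=O)c2cccc3ccccc23)c1`: < 5 ug/mL

In a physicochemical assay for solubility (on this read-out higher numbers stand for higher solubility and lower numbers for lower solubility), compound 1 gives 25 ug/mL and compound 2 gives 20 ug/mL. The step between them, a 1.3-fold lower number from compound 1 to compound 2 (0.10 log units; within the scatter), comes from one change, (amino in place of methoxy on a carbonyl carbon). In this assay compound 3 gives only a limit, < 5 ug/mL; this is the limit of < 5 ug/mL in this assay, at which 1 of the 3 values shown sits. The difference between the core of compound 1 and the core of compound 3 is not broken down here. Compound 4, `NC(=O)c1cccc(NC(=O)c2cccc3ccccc23)c1`, is not yet measured; it differs from compound 3 by the same change, (amino in place of methoxy on a carbonyl carbon), made at the same place. Because the measured step of a 1.3-fold lower number from compound 1 to compound 2 (0.10 log units; within the scatter) lies within the scatter, the step from compound 3 to compound 4 is expected to be small as well, a step that the limit leaves unreadable from compound 3 to compound 4. Compound 4 is therefore estimated at 4 ug/mL, between 1.5 ug/mL and 8 ug/mL, with a good chance that this assay again reports only a limit.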

Compound 4, solubility: 10 ug/mL
Beside the measured number, compound 4's estimate is 2.5-fold (0.40 log units) below it; measured number above the stated range.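

In this assay, amino in place of methoxy on a carbonyl carbon gives an at least 2.0-fold higher number from compound 3 to compound 4 (0.30 log units; that floor lies within the scatter), set against a 1.3-fold lower number from compound 1 to compound 2 (0.10 log units; within the scatter) on the core of compound 1. Compound 3 gives < 5 ug/mL, which is a limit and not a number. The result fits a small step on both cores but does not rule out a larger one on the core of compound 3, and the size of that step stays open because one end of it is a limit: the limit of < 5 ug/mL in this assay, at which 1 of the 4 values shown sits.

Only methoxy and amino appear on this carbonyl carbon, each on just two cores. Going by these compounds, how a carboxylic acid or a longer chain such as ethoxy would read in this assay remains open, on either core.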